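A few compounds are considered here, and "the series" means these few. Any claim that something is new, unique, unknown or untested is made for them only; others in the source may bear on it.

Measured so far in an in vivo functional assay on the whole organism (Rattus norvegicus) with cysteinyl leukotriene receptor (Homo sapiens) as the target; on this read-out higher numbers stand for an effect only at larger amounts of compound and lower numbers for an effect already at smaller amounts:
- compound 1 `CCCc1c(COc2ccc(C(=O)CCC(=O)O)cc2)ccc(C(C)=O)c1O`: 18.2 mg/kg
- compound 2 `CCCc1c(COc2ccc(C(=O)CC(C)(C)Cc3nnn[nH]3)cc2)ccc(C(C)=O)c1O`: 1.3 mg/kg

Among the measured compounds shown here, compound 2 holds the lower of the two numbers; the single known step, a 14-fold lower number from compound 1 to compound 2 (1.15 log units; beyond the scatter), separates it from compound 1. Compound 3 `CCCc1c(COc2ccc(C(=O)CCCCc3nnn[nH]3)cc2)ccc(C(C)=O)c1O` differs from compound 2 by 3-(1H-tetrazol-5-yl)propyl in place of 1-((1H-tetrazol-5-yl)methyl)-1-methylethyl on a saturated chain carbon bound to a carbonyl carbon. For the measured compounds named here, no measured step covers this change: the only step recorded concerns the exchange of carboxymethyl for the tetrazole-bearing group, which both compound 2 and compound 3 retain. With no evidence either way, the expected step of a 1.9-fold higher number from compound 2 to compound 3 (0.28 log units; within the scatter) is small, at most a modest rise. Compound 3 is therefore estimated at 2.5 mg/kg, with a range of 0.9 mg/kg to 7 mg/kg.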

Compound 3, dose for half-maximal effect: 2.4 mg/kg
Compound 3: the middle estimate sits 1.0-fold (0.02 log units) above what was measured; the range from low to high includes it.
By their numbers in this assay, from the lowest: compounds 2 and 3 (each within the scatter of the next); then compound 1.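

In this assay, 3-(1H-tetrazol-5-yl)propyl serves at this saturated chain carbon bound to a carbonyl carbon much as 1-((1H-tetrazol-5-yl)methyl)-1-methylethyl does, with a 1.8-fold higher number from compound 2 to compound 3 (0.27 log units; within the scatter), so the methyl-bearing group is not required here. The advantage over the carboxy end group of compound 1 persists without it, with a 7.6-fold lower number from compound 1 to compound 3 (0.88 log units; beyond the scatter) as the step. Nothing measured on these compounds bears on the reason for either step.

Open, from the compounds shown here alone, is whether a carboxylic acid at the end of the chain of compound 3 would match the tetrazole, which would separate end group from chain length. A longer chain carrying the tetrazole also remains to be placed against compound 3.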